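From a Methyl to a Chlorophenyl on the Shared Core

A few compounds are considered here, and "the series" means these few. Any claim that something is new, unique, unknown or untested is made for them only; others in the source may bear on it.

Three close analogues have been tested in a functional assay on COLO 320 cells (Homo sapiens) for antiproliferative activity, read by WST assay, with a stated time of 72 h; a higher number here means a weaker inhibitor, a lower number a stronger inhibitor. Compound 1 `COc1ccc2[nH]c(-c3nc(C)no3)cc2c1` gives 10400 nM. Compound 2 `Cc1noc(-c2cc3cc(F)ccc3[nH]2)n1` gives 18100 nM, and compound 3 `Cc1noc(-c2cc3cc(Cl)ccc3[nH]2)n1` gives 19500 nM. Compound 3 carries the highest of the three numbers, yet the gaps to its neighbours are small: a 1.9-fold higher number from compound 1 to compound 3 (0.27 log units; within the scatter) and a 1.1-fold higher number from compound 2 to compound 3 (0.03 log units; within the scatter), and likewise a 1.7-fold higher number from compound 1 to compound 2 (0.24 log units; within the scatter). The three compounds therefore cannot be told apart in this assay.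

Compound 4 `Clc1ccc(-c2noc(-c3cc4cc(Cl)ccc4[nH]3)n2)cc1` changes a different part of the shared core: 4-chlorophenyl in place of methyl on an aromatic carbon. For the measured compounds named here, none of the measured steps bears directly on this change; each of them exchanges a methoxy, fluoro or chloro group, and each stays within the scatter. Going by the values given here, the data thus give no precedent for replacing a methyl by a 4-chlorophenyl, so any expectation is loosely held and the range wide. Compound 4 is expected to give 9000 nM, between 2000 nM and 40000 nM. That estimate corresponds to an expected step of a 2.2-fold lower number from compound 3 to compound 4 (0.34 log units; beyond the scatter).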

Compound 4, half-maximal inhibitory concentration: 25000 nM
For compound 4 the middle estimate is 2.8-fold (0.44 log units) below the measured one; the range from low to high includes it.
By their numbers in this assay, from the lowest: compounds 1, 2, 3 and 4 (each within the scatter of the next, the first and the last beyond it).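

In this assay, placing a 4-chlorophenyl in place of methyl on the ring carbon between two ring nitrogen atoms gives a 1.3-fold higher number from compound 3 to compound 4 (0.11 log units; within the scatter), so compound 3 and compound 4 cannot be told apart. The earlier steps shown here exchanged only methoxy, fluoro and chloro groups at a different place, whereas this one shows that a far larger group, bringing a six-membered aromatic ring of carbon only, can stand at this position without a step beyond the scatter. Nothing available here explains this result.

From the compounds shown here alone, it remains open whether an amine, a carboxylic acid or a longer chain at this position would shift the number beyond the scatter. Going by these compounds, it is also open whether 4-chlorophenyl would behave the same way with methoxy or fluoro on the other side of the shared core.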